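Working notes: oxan-4-yl amide analogue of compound 3

The source may hold more compounds than are shown below. What is called first, only, known or untested is meant among the compounds shown, and "the series" means these compounds.

Measured compounds, with their numbers in a functional assay on CHO cells for antagonist activity at C-C chemokine receptor type 4 (Homo sapiens), read by GTPgammaS binding; a lower number here means a stronger inhibitor, a higher number a weaker inhibitor:
compound 1 `CC(=O)NCc1cccc(Cn2nc(NS(=O)(=O)c3ccc(Cl)s3)c3c(F)cccc32)c1` gives 79.4 nM
compound 2 `CC(=O)NCc1cccc(Cn2nc(NS(=O)(=O)c3ccc(Cl)s3)c3c(CO)cccc32)c1` gives 6.31 nM
compound 3 `COc1cccc2c1c(NS(=O)(=O)c1ccc(Cl)s1)nn2Cc1cccc(CNC(=O)C2COC2)c1` gives 20 nM

Compound 3 stands second highest of the three numbers in this assay. Compound 2 sits nearest to it, with a lower number by a margin beyond the scatter; compound 1 sits furthest, with a higher number, again beyond the scatter. Within the data shown here, the only single-change step among the measured compounds, a 13-fold lower number from compound 1 to compound 2 (1.10 log units; beyond the scatter), concerns a substituent on the core and has no counterpart in the change considered here.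

Compound 4 `COc1cccc2c1c(NS(=O)(=O)c1ccc(Cl)s1)nn2Cc1cccc(CNC(=O)C2CCOCC2)c1` differs from compound 3 in one place: oxan-4-yl in place of oxetan-3-yl on a carbonyl carbon. Among the measured compounds shown here, no measured pair in this set differs at the amide end of the molecule, so the measured compounds give no guide to how this assay responds to a change there. For the measured compounds named here, with no step bearing on it, the working expectation is a step of no size beyond the scatter, in neither direction, from compound 3 to compound 4.

Compound 4 is accordingly expected to give about 20 nM in this assay, with a range from 8 nM to 50 nM. The step this estimate implies, no change at the digits printed from compound 3 to compound 4 (within the scatter), is expected to stay within the scatter.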

Compound 4, half-maximal inhibitory concentration: 31.6 nM
Estimate against measurement, compound 4: 1.6-fold (0.20 log units) below; measured number inside the range.
By their numbers in this assay, from the lowest: compound 2; then compounds 3 and 4 (each within the scatter of the next); then compound 1.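

Working notes, amide end: in this assay, the step from oxetan-3-yl to oxan-4-yl on the carbonyl carbon gives a 1.6-fold higher number from compound 3 to compound 4 (0.20 log units; within the scatter), the first measured single-change step at this end of the molecule. In this one pair, therefore, going from a four-membered to a six-membered non-aromatic ring, with 4 and 6 heavy atoms respectively replaced by ring size alone and one hetero atom in each, does not separate the two compounds in this assay. No supporting measurement is available to explain this result.

From the compounds shown here alone, only these two oxygen-containing rings have been compared on this carbonyl carbon, so the tolerance of the position to a ring amine, a carboxylic acid or a longer open chain remains open. Also open, going by these compounds, is whether the core change seen in a 13-fold lower number from compound 1 to compound 2 (1.10 log units; beyond the scatter), hydroxymethyl in place of fluoro, would have a comparable effect in compounds bearing the oxetan-3-yl or oxan-4-yl amide.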